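Trifluoromethoxy for trifluoromethyl on the anilide of compound 2

The source may hold more compounds than are shown below. What is called first, only, known or untested is meant among the compounds shown, and "the series" means these compounds.

Measured compounds:
Compound 1 `COc1cccc(C(=O)NCN2CCC(c3cccc[n+]3[O-])CC2)c1C`: 685 nM
Compound 2 `O=C(CN1CCC(c2cccc[n+]2[O-])CC1)Nc1cccc(C(F)(F)F)c1`: 76 nM
Compound 3 `O=C(CN1CCC(c2cccc[n+]2[O-])CC1)Nc1ccc(F)cc1`: 85 nM

All three compounds were tested in a functional assay on HEK293 cells for agonist activity at D(4) dopamine receptor (Homo sapiens), read by FLIPR; on this read-out higher numbers stand for an effect only at larger amounts of compound and lower numbers for an effect already at smaller amounts. Compound 2 gives the lowest of the three numbers, 76 nM. Its nearest neighbour is compound 3, whose value of 85 nM lies within the scatter of repeated measurements, so the two cannot be told apart on these numbers. The furthest is compound 1 with 685 nM, a gap that lies beyond the scatter; compound 1 also differs from the other two in more than one place, so nothing is said here about what causes that gap.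

Compound 4 `O=C(CN1CCC(c2cccc[n+]2[O-])CC1)Nc1cccc(OC(F)(F)F)c1` has not yet been measured. It differs from compound 2 in one place: trifluoromethoxy in place of trifluoromethyl on an aromatic carbon.

Among the measured compounds shown here, no step between two measured compounds isolates this kind of exchange, so the expectation for compound 4 rests on compound 2 alone. The change is small in the count of atoms, and the expected step is small: the step from a 1.2-fold higher number from compound 2 to compound 4 (0.07 log units; within the scatter) is estimated to fall within the scatter, with no clear direction. Compound 4 is therefore expected to give about 90 nM in this assay, with a range from 35 nM to 250 nM.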

Compound 4, half-maximal effective concentration: 135 nM
Estimate against measurement, compound 4: 1.5-fold (0.18 log units) below; measured number inside the range.
By their numbers in this assay, from the lowest: compounds 2, 3 and 4 (each within the scatter of the next); then compound 1.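

In this assay, among the compounds shown here, putting trifluoromethoxy in place of trifluoromethyl on this aromatic carbon gives a 1.8-fold higher number from compound 2 to compound 4 (0.25 log units; within the scatter), the first step that isolates a change at a single place. For the compounds shown here, the position therefore accepts the extra oxygen, with its added hydrogen-bond acceptor in the count, without a step that can be told apart from repeated measurement, something the earlier compounds, with no single-place step among them, could not show. Nothing available here bears on why the two groups read alike on this assay.

What the compounds shown leave open is how far this tolerance reaches, since a single step within the scatter sets no limit on what this aromatic carbon accepts, and a nitrile, a carboxylic acid or an amine in the same place might behave quite differently. Also open, going by these compounds, is whether the same exchange, made on another aromatic carbon of the ring or on a different anilide, would give a step of similar size.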